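A few compounds are considered here, and "the series" means these few. Any claim that something is new, unique, unknown or untested is made for them only; others in the source may bear on it.

Measured in a functional assay on BEAS-2B cells (Homo sapiens) for inhibition, read by MTT assay, with a stated time of 72 h; a higher number here means a weaker inhibitor, a lower number a stronger inhibitor:
Compound 1 `C=C(c1ccc(Cl)cc1Cl)C1COC2(CCCC2)OO1`: 17400 nM
Compound 2 `C=C(c1ccc(OC)c(F)c1)C1COC2(CCCC2)OO1`: 55800 nM

Only these two numbers exist so far. Compound 2, at 55800 nM, has the higher number and is therefore the weaker inhibitor of the pair, and its gap to compound 1 lies beyond the scatter. Compound 3 `C=C(c1ccc(F)c(F)c1)C1COC2(CCCC2)OO1` keeps the core of compound 2 but has fluoro in place of methoxy on an aromatic carbon, ortho to a fluoro group and para to a large group (fluoro in place of methoxy on an aromatic carbon). Among the compounds with values here, no measured pair shows this change on its own, so the expectation rests on thin evidence. Within the data shown here, the only hint is compound 1, which has no methoxy group and gives 17400 nM. The estimated change, a 1.9-fold lower number from compound 2 to compound 3 (0.27 log units; within the scatter), is a small move towards a lower number that may stay within the scatter. Compound 3 is expected at 30000 nM, with an estimated range from 12000 nM to 75000 nM.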

Compound 3, half-maximal inhibitory concentration: 73600 nM
For compound 3 the middle estimate is 2.5-fold (0.39 log units) below the measured one; the measured number falls inside the stated range.
By their numbers in this assay, from the lowest: compound 1; then compounds 2 and 3 (each within the scatter of the next).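

Fluoro in place of methoxy on this aromatic carbon, ortho to a fluoro group and para to a large group, now has a measured step of its own: the result in this assay is a 1.3-fold higher number from compound 2 to compound 3 (0.12 log units; within the scatter) and lies within the scatter. Compound 2 and compound 3 therefore cannot be told apart in this test, even though methoxy and its hydrogen-bond acceptor have left the ring. Within the data shown here, nothing measured so far offers an explanation for this result.

On these data alone, what an amine, a hydroxyl group or a longer chain such as ethoxy would do at this position stays open. Compound 1 differs from compound 2 in more than one place, so which of its differences accounts for its lower number also stays open.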